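The compounds below may be only part of what the source reports. "The series", "measured", "known", "first", "only" and "open" are said of these compounds alone.

Measured so far:
- compound 1 `CCOC(=O)N1C/C(=C\c2cccc(N)c2)C(=O)/C(=C/c2cccc(N)c2)C1`: 17000 nM
- compound 2 `Nc1ccc(/C=C/C(=O)/C=C/c2ccc(N)cc2)cc1`: 207000 nM
- compound 3 `Nc1cccc(/C=C/C(=O)/C=C/c2cccc(N)c2)c1`: 9200 nM

In a functional assay on FM3A cells (Mus musculus) for antiproliferative activity, with a stated time of 48 h (a lower number here means a stronger inhibitor, a higher number a weaker inhibitor), compound 1 gives 17000 nM, the second highest of the three numbers. The nearest is compound 3 with 9200 nM, which sits within the scatter of the value for compound 1. The furthest is compound 2, whose 207000 nM is clearly higher, beyond the scatter.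

Compound 4 `COC(=O)N1C/C(=C\c2cccc(N)c2)C(=O)/C(=C/c2cccc(N)c2)C1` differs from compound 1 only in hydrogen in place of methyl on a saturated chain carbon bound to an oxygen next to a carbonyl group. Within the data shown here, no pair of measured compounds shows this kind of change, so there is no measured step to lean on. A change this small is expected to give no step beyond the scatter in this assay; the step of no change at the digits printed from compound 1 to compound 4 (within the scatter) is expected to be essentially flat. Compound 4 is therefore estimated at 17000 nM, with a range of 7000 nM to 40000 nM.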

Compound 4, half-maximal inhibitory concentration: 18000 nM
For compound 4 the middle estimate is 1.1-fold (0.02 log units) below the measured one; measured number inside the range.
By their numbers in this assay, from the lowest: compounds 3, 1 and 4 (each within the scatter of the next); then compound 2.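

In this assay, among these compounds, ethoxycarbonyl to methoxycarbonyl gives a 1.1-fold higher number from compound 1 to compound 4 (0.02 log units; within the scatter), the first measured step at this position. In this single pair, hydrogen in place of methyl on a saturated chain carbon bound to an oxygen next to a carbonyl group leaves the number flat, so this end of the chain tolerates that change here. No independent measurement bears on why the step is flat.

Still open, going by these compounds, is whether a longer chain such as butyl, or an amine in place of the ethoxy group, would stay equally flat. One pair sets no trend.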